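Enlarging an amide substituent where only limits exist

The compounds below may be only part of what the source reports. "The series", "measured", "known", "first", "only" and "open" are said of these compounds alone.

In a toxicity assay on cells (Cricetulus griseus) for cytotoxicity, read by MTT assay, with a stated time of 72 h (on this read-out lower numbers stand for stronger inhibition and higher numbers for weaker inhibition), compound 3 `Cc1c(C)c2c(c(C)c1OC(=O)CCC(=O)NC1CC(C)(C)N([O])C1(C)C)CC[C@@](C)(CCC[C@H](C)CCC[C@H](C)CCCC(C)C)O2` gives > 300000 nM, which is a limit and not a number. Compound 1 `Cc1c(C)c2c(c(C)c1OC(=O)CCC(=O)NC1CC(C)(C)N([O])C(C)(C)C1)CC[C@@](C)(CCC[C@H](C)CCC[C@H](C)CCCC(C)C)O2` gives > 300000 nM, also a limit. Compound 2 `CC1(C)CC(NC(=O)CCC(=O)O)CC(C)(C)N1[O]` gives > 300000 nM, again a limit. Compound 3 therefore shares its place with both others, as shown by the limit of > 300000 nM in this assay, at which 3 of the 3 values shown sit.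

Compound 4 `Cc1c(C)c2c(c(C)c1OC(=O)CCC(=O)NCC1CC(C)(C)N([O])C1(C)C)CC[C@@](C)(CCC[C@H](C)CCC[C@H](C)CCCC(C)C)O2` differs from compound 3 on an amide-type nitrogen: a group of 11 heavy atoms (9 carbon, 1 nitrogen, 1 oxygen; one five-membered non-aromatic ring with 1 hetero atom) in place of a group of 10 heavy atoms (8 carbon, 1 nitrogen, 1 oxygen; one five-membered non-aromatic ring with 1 hetero atom), on an amide-type nitrogen. Among the compounds with values here, the one measured step bearing on this is a step that the two limits leave unreadable from compound 1 to compound 3, which also changed the group on that nitrogen. With no readable size to build on, no shift beyond the scatter is expected, and the expected a number no higher from compound 3 to compound 4 (the limit leaves the size open) has no predicted direction. Compound 4 is estimated at 300000 nM, with an expected range from 150000 nM to 600000 nM.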

Compound 4, half-maximal inhibitory concentration: > 300000 nM
Compound 4 ended at the assay's limit; the forecaster's own chance of this, stated with the estimate: 90%; the middle value sits exactly at the limit.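

No step can be read among compound 1, compound 3 and compound 4, since each gives only a limit and not a number: the limit of > 300000 nM in this assay, at which 4 of the 4 values shown sit.

The compounds shown leave open whether changing the group on the amide-type nitrogen has any effect in this assay.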